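Methyl on the benzyl ring and endothelial cytotoxicity

The source may report more compounds than this note shows. Statements on the series, on what has been measured and on what is new or still open speak of the compounds shown alone.

Three compounds share a core built around an oxime ether that carries a benzyl group, and all three were tested in an ADME assay on HUVEC cells (Homo sapiens) for cytotoxicity, read by MTT assay, with a stated time of 2 days; a lower number here means a stronger inhibitor, a higher number a weaker inhibitor. Compound 1 is `c1ccc(CO/N=C2/C(c3c[nH]c4ccccc34)=Nc3ccccc32)cc1` and carries an unsubstituted benzyl group. In this assay compound 1 gives > 100000 nM, which is a limit of the assay rather than a number. Compound 3 is `Cc1ccc(CO/N=C2/C(c3c[nH]c4ccccc34)=Nc3ccccc32)cc1` and differs from compound 1 by methyl in place of hydrogen on an aromatic carbon. In this assay compound 3 gives > 100000 nM, again a limit of the assay. The step that the two limits leave unreadable from compound 1 to compound 3 therefore cannot be read, since both ends of it sit at the same limit.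

Compound 2 is `Fc1ccc2c(c1)/C(=N\OCc1ccccc1)C(c1c[nH]c3ccc(F)cc13)=N2`; how its core differs from the core of compound 1 is not broken down here. In this assay compound 2 gives > 100000 nM, a limit of the assay.

Compound 4 is `Cc1ccc(CO/N=C2/C(c3c[nH]c4ccc(F)cc34)=Nc3ccc(F)cc32)cc1` and has not been measured. Among the compounds with values here, it differs from compound 2 by methyl in place of hydrogen on an aromatic carbon, the same change as the one from compound 1 to compound 3, made at the same kind of place.

Within the data shown here, the step that the limit leaves unreadable from compound 2 to compound 4 is expected to be of the same unreadable kind as a step that the two limits leave unreadable from compound 1 to compound 3, because the limit of > 100000 nM in this assay, at which 3 of the 3 values shown sit, shows every value so far resting at the limit. For compound 4 the expected result is 150000 nM, with a range from 70000 nM to 400000 nM.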

Compound 4, half-maximal inhibitory concentration: > 100000 nM
Compound 4 ended at the assay's limit; the forecaster's own chance of this, stated with the estimate: 85%; the middle value does not contradict the limit.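

Compound 2 and compound 4 both sit at a limit of the assay rather than at a number, so no new step can be read from this result: the limit of > 100000 nM in this assay, at which 4 of the 4 values shown sit.

The compounds shown leave open whether swapping benzyl for 4-methylbenzyl changes the result in this assay at all, and how any of these compounds would compare with one another at a readable value.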